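Swapping a difluorophenyl for a nitrophenyl on the thioether arm

The source may report more compounds than this note shows. Statements on the series, on what has been measured and on what is new or still open speak of the compounds shown alone.

Of the compounds shown here, three sharing one core have been tested in a functional assay on HepG2 cells (Homo sapiens) for inhibition, read by MTT assay, with a stated time of 48 h; a lower number here means a stronger inhibitor, a higher number a weaker inhibitor. Compound 1 `Fc1ccccc1CSc1nnc(-c2ccncc2)n1-c1ccccc1` reaches only the assay limit, > 50000 nM (the limit of > 50000 nM in this assay, at which 1 of the 3 values shown sits). Compound 2 `Clc1ccc(CSc2nnc(-c3ccncc3)n2-c2ccccc2)cc1` gives 16900 nM in this assay, and compound 3 `Fc1ccc(CSc2nnc(-c3ccncc3)n2-c2ccccc2)c(F)c1` gives 10200 nM. Compound 3 thus holds the lowest of the two real numbers, though the step between these two is only a 1.7-fold lower number from compound 2 to compound 3 (0.22 log units; within the scatter), which is within the scatter.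

Compound 4 `O=[N+]([O-])c1ccccc1CSc1nnc(-c2ccncc2)n1-c1ccccc1` is not yet measured. It differs from compound 3 by 2-nitrophenyl in place of 2,4-difluorophenyl on a saturated chain carbon bound to a sulfur. For the measured compounds named here, the nearest measured steps are an at least 2.9-fold lower number from compound 1 to compound 2 (0.47 log units; beyond the scatter) and an at least 4.9-fold lower number from compound 1 to compound 3 (0.69 log units; beyond the scatter); both start from compound 1, the only member carrying a single substituent at the 2-position of the phenyl, and both lead away from the limit to real numbers. Compound 4 returns to a phenyl substituted only at that 2-position, so a climb back toward weaker inhibition is expected, roughly a 2.9-fold higher number from compound 3 to compound 4 (0.47 log units; beyond the scatter). The expected value for compound 4 in this assay is 30000 nM, within 10000 nM to 90000 nM.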

Compound 4, half-maximal inhibitory concentration: > 50000 nM
Compound 4: no number, only a limit; the forecaster's own chance of this, stated with the estimate: 40%; middle value at least 1.6-fold (0.22 log units) away from the limit.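

Compound 4 gives only a limit in this assay, and so does compound 1: the limit of > 50000 nM in this assay, at which 2 of the 4 values shown sit. At this place on a saturated chain carbon bound to a sulfur, 2-nitrophenyl in place of 2,4-difluorophenyl costs the measurable inhibition, with an at least 4.9-fold higher number from compound 3 to compound 4 (0.69 log units; beyond the scatter), and the comparison with 4-chlorophenyl agrees, with an at least 2.9-fold higher number from compound 2 to compound 4 (0.47 log units; beyond the scatter). Both compounds with one group, 2-fluorophenyl or 2-nitrophenyl, now sit at the limit, though compound 3 shows that a group named at the 2-position does not by itself rule out a number.

As far as these compounds go, the step between compound 1 and compound 4 cannot be read, so how those two compare stays unknown. Also open, from the compounds shown here alone, is whether an amine or a carboxylic acid on this phenyl ring would give a real number.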